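A few compounds are considered here, and "the series" means these few. Any claim that something is new, unique, unknown or untested is made for them only; others in the source may bear on it.

Measured so far in a functional assay (trachea) for antagonist activity, with Cavia porcellus as the target; on this read-out higher numbers stand for higher potency (the scale is a negative logarithm) and lower numbers for lower potency:
compound 1 `COC(=O)C(C(=O)c1ccc(Cn2ccc3ccc(NC(=O)CC4CCCC4)cc32)c(OC)c1)S(=O)(=O)c1ccccc1` gives 10.1
compound 2 `CCCCC(CC)C(=O)Nc1ccc2ccn(Cc3ccc(C(=O)NS(=O)(=O)c4ccc(OC)cc4)cc3OC)c2c1` gives 7.4

Compound 2 stands lowest of the two numbers in this assay; compound 1 is the nearest, a gap well beyond the scatter. Compound 3 `CCCCC(CC)C(=O)Nc1ccc2ccn(Cc3ccc(C(=O)C(C#N)S(=O)(=O)c4ccccc4)cc3OC)c2c1` is not yet measured. It differs from compound 2 by cyano(phenylsulfonyl)methyl in place of ((4-methoxyphenyl)sulfonyl)amino on a carbonyl carbon. Among the compounds with values here, no measured pair shows this step directly, so its size is inferred: a sizeable rise in this assay is expected, because compound 1 gives 10.1 with a ketone head group of a closely related kind. The step from a number 1.90 log units higher from compound 2 to compound 3 (beyond the scatter) is the expected gain. Compound 3 is estimated at 9.3, range 8.3 to 10.3.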

Compound 3, negative logarithm of the antagonist equilibrium constant: 8.1
Compound 3: the middle estimate sits 1.20 log units above what was measured; measured number below the stated range.
By their numbers in this assay, from the lowest: compound 2; then compound 3; then compound 1.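

Replacing ((4-methoxyphenyl)sulfonyl)amino with cyano(phenylsulfonyl)methyl on a carbonyl carbon gives, in this assay, a number 0.70 log units higher from compound 2 to compound 3 (beyond the scatter). At this position, activity therefore survives the loss of the hydrogen-bond donor counted in the leaving group, and the sulfonyl amino link is not required. No measurement shown bears on the reason for this rise. Still open, as far as these compounds go, is what the nitrile itself adds to the entering group: a primary amide or a plain hydrogen in its place would separate it from the phenylsulfonyl part.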